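The source may hold more compounds than are shown below. What is called first, only, known or untested is meant among the compounds shown, and "the series" means these compounds.

Working notes on the series. The shared core carries a methylsulfonylphenyl group on one ring nitrogen, and the aryl group on the carbon with a double bond to nitrogen is varied. In a functional assay on the whole organism (strain Wistar) for inhibition, with Rattus norvegicus as the target, read by paw edema, with stated times of 30 min and 5 h, at a dose of 0.05 mmol/kg by the oral route (on this read-out higher numbers stand for more inhibition at the one dose given (going by the name of the read-out) and lower numbers for less inhibition), compound 1 `Cc1cc(O)ccc1C1=NN(c2ccc(S(C)(=O)=O)cc2)C(=O)CC1` gives 52.6%. Compound 2 `COc1ccc(C2=NN(c3ccc(S(C)(=O)=O)cc3)C(=O)CC2)cc1OC` gives 82.4% in this assay. Compound 1 thus stands lowest of the two numbers measured, with compound 2 the nearest and higher by a margin beyond the scatter. Within the data shown here, no pair that differs in a single place has been measured, so the size of a single change is not known for this assay.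

Compound 3 `CS(=O)(=O)c1ccc(N2N=C(c3ccc(Cl)cc3)CCC2=O)cc1` is not yet measured. It differs from compound 1 as follows: 4-chlorophenyl in place of 4-hydroxy-2-methylphenyl on a carbon with a double bond to nitrogen. Only two measured points exist, and neither shows what a 4-chlorophenyl group does here. The expectation for compound 3 in this assay is a step of a number 7.4 percentage points higher from compound 1 to compound 3 (within the scatter), that is, no change beyond the scatter and, if anything, slightly upward. Compound 3 is estimated at 60% in this assay, within a range from 35% to 85%.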

Compound 3, a percentage reported as inhibition, in the whole organism at one dose (the size of the read-out at that dose, not a potency): 36.8%
Estimate against measurement, compound 3: 23.2 percentage points above; measured number inside the range.
By their numbers in this assay, from the lowest: compound 3; then compound 1; then compound 2.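

In this assay, among these compounds, the 4-chlorophenyl group in place of 4-hydroxy-2-methylphenyl on the carbon with a double bond to nitrogen gives a number 15.8 percentage points lower from compound 1 to compound 3 (beyond the scatter) and this is the first single-place step, so the read-out does respond to the aryl group at this position. The step is modest, yet it combines several changes: the hydroxy and methyl groups both leave, the hydrogen-bond donor and acceptor counted on the leaving group go with them, and chlorine enters, so the step cannot be divided among these parts. Nothing measured here bears on the reason for the step.

The compounds shown leave open whether the hydroxy or the methyl group of compound 1 carries the difference, as none of them has one of these groups without the other. Also open, going by these compounds, is how 4-hydroxyphenyl, 2-methylphenyl, 4-fluorophenyl or an aryl group bearing an amine or a carboxylic acid at this position would read in this assay.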